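The compounds below may be only part of what the source reports. "The series", "measured", "known", "first", "only" and "open" are said of these compounds alone.

Compound 1 `COc1ccc(C2N=C(SCc3cccc(Cl)c3)NC(C)=C2C(=O)Nc2ccc(F)cc2)cc1OC`: 13.4%
Compound 2 `COc1ccc(C2N=C(SCc3ccc(Cl)cc3)NC(C)=C2C(=O)Nc2ccc(Br)cc2)cc1`: 22.7%
Compound 3 `CC1=C(C(=O)Nc2ccc([N+](=O)[O-])cc2)C(c2ccc(Br)cc2)N=C(SCc2ccccc2Cl)N1`: 11.3%

These three compounds share one core and were tested in a functional assay on the whole organism (artery, strain albino) with Rattus norvegicus as the target, with a stated time of 180 min, at a dose of 10 mg/kg by the oral route; a higher number here means more inhibition at the dose given (going by the name of the read-out), a lower number less inhibition. Compound 3 has the lowest of the three numbers, yet its gap to compound 1 lies within the scatter, so the two cannot be told apart; only compound 2 stands clearly above it, beyond the scatter. Compound 4 `CC1=C(C(=O)Nc2ccc([N+](=O)[O-])cc2)C(c2ccc(Br)cc2)N=C(SCc2ccc(Cl)cc2)N1` has not yet been measured. It differs from compound 3 in one place: 4-chlorophenyl in place of 2-chlorophenyl on a saturated chain carbon bound to a sulfur. Going by the values given here, no pair of measured compounds differs by this change alone, so no measured step shows what it does. Compound 2 also carries the 4-chlorobenzyl group, but it differs from compound 3 in further places as well, so its value says nothing about this change on its own. The step from compound 3 to compound 4 in this assay is expected to be small, a number 3.7 percentage points higher from compound 3 to compound 4 (within the scatter), and not clearly beyond the scatter. For compound 4 the estimated inhibition is 15%, with a range from 5% to 28%.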

Compound 4, a percentage reported as inhibition, in the whole organism at one dose (the size of the read-out at that dose, not a potency): 19.1%
Compound 4: middle estimate off by 4.1 percentage points, on the low side; the range from low to high includes it.
By their numbers in this assay, from the lowest: compounds 3, 1, 4 and 2 (each within the scatter of the next, the first and the last beyond it).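

Exchanging 2-chlorophenyl for 4-chlorophenyl on a saturated chain carbon bound to a sulfur gives, in this assay, a number 7.8 percentage points higher from compound 3 to compound 4 (within the scatter), so the two compounds cannot be told apart. Going by these compounds alone, this is the first direct reading of this change, with the rest of the molecule held the same, and it shows no clear effect of where the chlorine sits on this ring, at least between these two compounds. No measurement at hand bears on why the result looks this way.

Within the data shown here, compound 1 and compound 2 differ from compound 4 in more than one place, so no steps to them can be read. Every compound shown carries a chlorobenzyl group here, which leaves open what a plain benzyl group, a longer chain such as phenethyl, or an amine in this place would give.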